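This account rests on a few compounds, and the source may have more. Where it says the series, first, only, none or still open, it means among the compounds named here.

Working notes on the series. Compound 1 `C[C@H](Nc1nc(N)nc(N)c1C#N)c1nn(-c2cccc(S(C)(=O)=O)c2)c2cc(F)ccc12` and compound 2 `C[C@H](Nc1ncnc2[nH]cnc12)c1nn(-c2cccnc2)c2ccc(F)cc12` have both been run in a functional assay on Hep 3B2 cells (Homo sapiens) for inhibition, read by sulforhodamine B assay, with a stated time of 72 h, tested at 10 uM; on this read-out lower numbers stand for less inhibition and higher numbers for more inhibition at the one concentration tested (going by the name of the read-out). In this assay compound 1 gives 36%, while compound 2 gives 13%. Compound 2 therefore stands at the lowest of the two numbers in hand; its nearest neighbour is compound 1, whose number lies higher by a margin beyond the usual scatter. Within the data shown here, no pair of measured compounds differs in a single place, so no measured single step is available to calibrate the next move.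

Compound 3 `Cc1ccc2c(c1)c([C@H](C)Nc1ncnc3[nH]cnc13)nn2-c1cccnc1` is the next compound for this assay. It differs from compound 2 in one place: methyl in place of fluoro on an aromatic carbon The change sits on an aromatic carbon of a six-membered aromatic ring of carbon only, part of a fused or bridged system of two rings, and swaps one heavy atom for one heavy atom.

Among the measured compounds shown here, with no measured step of this kind, the expectation rests on the low number of compound 2 alone. The step expected in this assay is a number 2 percentage points higher from compound 2 to compound 3 (within the scatter), which is to say none beyond the scatter. Compound 3 is estimated to give 15% in this assay, within a range from 0% to 35%.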

Compound 3, a percentage reported as inhibition, at one concentration (the size of the read-out at that concentration, not a potency): 8%
Beside the measured number, compound 3's estimate is 7 percentage points above it; the measured number falls inside the stated range.
By their numbers in this assay, from the lowest: compounds 3 and 2 (each within the scatter of the next); then compound 1.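

In this assay, among these compounds, the exchange of fluoro for methyl on an aromatic carbon of the six-membered aromatic ring of carbon only provides the first measured single step, which reads a number 5 percentage points lower from compound 2 to compound 3 (within the scatter) and so shows no change beyond the scatter. At this position, then, fluoro and methyl cannot be told apart on this read-out, and this one step gives no reason to prefer either group when the rest of the structure is that of compound 2. Nothing measured here bears on why the two groups read alike.

Still open, as far as these compounds go, is whether a group of a different kind on the same aromatic carbon, such as an amine, a methoxy group or a carboxylic acid, would move the number beyond the scatter, since a swap of one heavy atom for one heavy atom samples only a narrow part of what could be placed at this position. Also open, from the compounds shown here alone, is whether the exchange of fluoro for methyl would read the same way on the core of compound 1, which differs from compound 2 in more than one place.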